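A few compounds are considered here, and "the series" means these few. Any claim that something is new, unique, unknown or untested is made for them only; others in the source may bear on it.

Measured in a functional assay on MDA-MB-231 cells (Homo sapiens) for cytotoxicity, read by MTT assay, with a stated time of 72 h; on this read-out lower numbers stand for stronger inhibition and higher numbers for weaker inhibition:
Compound 1 `CN(C)Cc1ccc2nc(NC(=O)N/N=C/c3c[nH]c4ccccc34)sc2c1`: 1190 nM
Compound 2 `CN(C)Cc1ccc2nc(NC(=O)N/N=C/c3cn(Cc4ccccc4)c4ccccc34)sc2c1`: 1340 nM

Compound 2, at 1340 nM, cannot be told apart from compound 1, at 1190 nM. The two values lie within the scatter of each other. Compound 3 `CN(C)Cc1ccc2nc(NC(=O)N/N=C/c3cn(Cc4ccc(Cl)cc4)c4ccccc34)sc2c1` follows from compound 2 by chloro in place of hydrogen on an aromatic carbon, which turns benzyl into 4-chlorobenzyl. Chloro in place of hydrogen on an aromatic carbon has not itself been measured in this series. Within the data shown here, only one measured step bears on the change, the one that introduced the benzyl group, and it came to a 1.1-fold higher number from compound 1 to compound 2 (0.05 log units; within the scatter). That single step gives little to go on, but it offers no sign of a large effect at this part of the molecule, so no shift beyond the scatter is expected in this assay. The expected change is a 1.3-fold lower number from compound 2 to compound 3 (0.13 log units; within the scatter). For compound 3 the estimated value is 1000 nM, with an expected range of 450 nM to 2200 nM.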

Compound 3, half-maximal inhibitory concentration: 880 nM
The estimate for compound 3 lay 1.1-fold (0.06 log units) above the measured number, within the range that was stated.
By their numbers in this assay, from the lowest: compounds 3, 1 and 2 (each within the scatter of the next).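

In this assay, chloro in place of hydrogen on an aromatic carbon, para to a large group, comes to a 1.5-fold lower number from compound 2 to compound 3 (0.18 log units; within the scatter), so the first substitution on the phenyl of the benzyl group itself does not separate compound 3 from compound 2. Measured against the unsubstituted aromatic nitrogen, 4-chlorobenzyl in place of hydrogen comes to a 1.4-fold lower number from compound 1 to compound 3 (0.13 log units; within the scatter), so neither benzyl nor 4-chlorobenzyl on that nitrogen has yet moved the number beyond the scatter. No measurement at hand offers an explanation for these values.

From the compounds shown here alone, it remains open whether a different group at this place on the phenyl, such as methoxy, an amine or a carboxylic acid, would give a step beyond the scatter. Equally open, going by these compounds, is whether a longer chain on the aromatic nitrogen, in place of benzyl, would do so.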